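Changing the Sulfonyl Aryl Group: Clearance Outlook for Compound 4

A few compounds are considered here, and "the series" means these few. Any claim that something is new, unique, unknown or untested is made for them only; others in the source may bear on it.

Measured compounds in an ADME assay on microsomes from liver (Homo sapiens) for metabolic stability, tested at 2.5 uM; on this read-out lower numbers stand for slow clearance and higher numbers for fast clearance:
Compound 1, `COc1cccc(-c2c(S(=O)(=O)c3ccc(OC)c(Cl)c3)cnc3cc(F)ccc23)c1`: 1.71 mL/min
Compound 2, `COc1cccc(S(=O)(=O)c2cnc3cc(F)ccc3c2-c2cccc(Cl)c2)c1`: 2.97 mL/min
Compound 3, `O=S(=O)(c1ccc(F)c(F)c1)c1cnc2cc(F)ccc2c1-c1cccc(Cl)c1`: 0.38 mL/min

Compound 3 stands lowest of the three in this assay; compound 1 gives 1.71 mL/min, and compound 2 gives 2.97 mL/min, both beyond the scatter above it. Among the compounds with values here, the one measured step that touches the group on the sulfonyl sulfur is a 7.8-fold lower number from compound 2 to compound 3 (0.89 log units; beyond the scatter), a modest move downward. Compound 4, `COc1ccc(S(=O)(=O)c2cnc3cc(F)ccc3c2-c2cccc(Cl)c2)cc1Cl`, has not yet been measured; it differs from compound 3 as follows: 3-chloro-4-methoxyphenyl in place of 3,4-difluorophenyl on a sulfonyl sulfur.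

Within the data shown here, the only further hint on the entering group comes from compound 1, which carries 3-chloro-4-methoxyphenyl on the sulfonyl sulfur but a different group on the core, so no direct step exists; its value sits between compound 2 and compound 3. Since the step from compound 2 to compound 3 ran downward when 3,4-difluorophenyl entered, compound 4 is expected to move back upward, though not fully, because compound 1 gives 1.71 mL/min. The expected step is a 3.9-fold higher number from compound 3 to compound 4 (0.60 log units; beyond the scatter). Compound 4 is therefore estimated at 1.5 mL/min, within a range of 0.7 mL/min to 3.2 mL/min.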

Compound 4, intrinsic clearance in a liver preparation (reported as CLH), per the amount of preparation that the assay uses: 1.19 mL/min
Estimate against measurement, compound 4: 1.3-fold (0.10 log units) above; low and high end bracket the measured number.
By their numbers in this assay, from the lowest: compound 3; then compounds 4, 1 and 2 (each within the scatter of the next, the first and the last beyond it).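

In this assay, the 3-chloro-4-methoxyphenyl group on the sulfonyl sulfur does not match 3,4-difluorophenyl, with a 3.1-fold higher number from compound 3 to compound 4 (0.50 log units; beyond the scatter), yet it also differs from 3-methoxyphenyl, with a 2.5-fold lower number from compound 2 to compound 4 (0.40 log units; beyond the scatter). The three groups compared at this place therefore separate beyond the scatter, with 3,4-difluorophenyl giving the lowest number and 3-methoxyphenyl the highest. With 3-chloro-4-methoxyphenyl held on the sulfur, chloro in place of methoxy on an aromatic carbon gives a 1.4-fold lower number from compound 1 to compound 4 (0.16 log units; within the scatter), so that second change has no readable effect on this read-out.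

Nothing available accounts for these differences. The compounds shown leave open how this read-out responds to a sulfonyl group bearing something other than a substituted phenyl, such as a pyridine ring, a morpholine or a simple amine.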